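Removing the phenyl from compound 1

The source may hold more compounds than are shown below. What is called first, only, known or untested is meant among the compounds shown, and "the series" means these compounds.

Measured in a functional assay on MDCK cells (Canis lupus familiaris) for inhibition; on this read-out lower numbers stand for higher toxicity in this test and higher numbers for lower toxicity in this test:
- compound 1 `COc1nc(CC2(c3ccccc3)CCCO2)cc(=O)n1C`: 130000 nM
- compound 2 `CCCOc1nc(CC2(c3ccccc3)CCCO2)cc(=O)n1C`: 170000 nM
- compound 3 `CCCCOc1nc(CC2(c3ccccc3)CCCO2)cc(=O)n1C`: 90000 nM

Compound 1 stands together with the other two compounds, since its numbers and theirs all lie within the scatter of one another. The next compound, compound 4 `COc1nc(CC2CCCO2)cc(=O)n1C`, changes a different part of the molecule: hydrogen in place of phenyl on a saturated ring carbon. This is hydrogen in place of phenyl on a saturated ring carbon.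

The measured steps all concern the chain on the oxygen at the other end of the molecule. They are a 1.3-fold higher number from compound 1 to compound 2 (0.12 log units; within the scatter), a 1.4-fold lower number from compound 1 to compound 3 (0.16 log units; within the scatter) and a 1.9-fold lower number from compound 2 to compound 3 (0.28 log units; within the scatter), and each stays within the scatter. They show that this assay barely registered those chain changes, but none of them touches the phenyl, so they bear on this change only indirectly. Among the compounds with values here, no measured compound lacks the phenyl, so the direction is a tentative guess: a small move towards a higher number, possibly none beyond the scatter, with a wide range.

The estimate implies a 1.5-fold higher number from compound 1 to compound 4 (0.19 log units; within the scatter) as the expected step. For compound 4 the expected value is 200000 nM, with an estimated range from 90000 nM to 450000 nM.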

Compound 4, half-maximal cytotoxic concentration: 1220000 nM
Beside the measured number, compound 4's estimate is 6.1-fold (0.79 log units) below it; measured number outside the range, above it.
By their numbers in this assay, from the lowest: compounds 3, 1 and 2 (each within the scatter of the next); then compound 4.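

In this assay, this position matters far more than the chain changes suggested: hydrogen in place of phenyl on the saturated ring carbon next to the ring oxygen gives a 9.4-fold higher number from compound 1 to compound 4 (0.97 log units; beyond the scatter). Within the data shown here, the steps among compounds 1, 2 and 3 all stay within the scatter, so this is the first change that the test clearly registers, and it moves towards lower toxicity in this test. Nothing available explains why removing the phenyl has this effect, so the result records what happens at this position but not the reason for it.

Phenyl and hydrogen are only two possible groups at this position, so it remains open whether a methyl, a cyclohexyl or a fluorophenyl would give a number close to that of compound 1, close to that of compound 4, or somewhere in between. As far as these compounds go, it is also open whether the same change would give a step of similar size on the longer chains of compound 2 and compound 3, since this single step starts from compound 1 alone.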